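Halogen Swap at the Ortho Position of the Oxadiazole Thiol Series

This account rests on a few compounds, and the source may have more. Where it says the series, first, only, none or still open, it means among the compounds named here.

Measured compounds:
compound 1 `Sc1nnc(-c2ccccc2Cl)o1` — 680 nM
compound 2 `Cc1cccc(-c2nnc(S)o2)c1` — 1100 nM
compound 3 `Fc1ccccc1-c1nnc(S)o1` — 190 nM

In an assay (Populus sieboldii x Populus grandidentata) for inhibition of Trans-cinnamate 4-monooxygenase (Populus kitakamiensis), with a stated time of 60 min (on this read-out higher numbers stand for weaker inhibition and lower numbers for stronger inhibition), compound 3 gives the lowest number of the three, beyond the scatter from both of the others. Within the data shown here, compound 1 stands closest to it, and the only single-point step among the measured compounds runs between these two: a 3.6-fold lower number from compound 1 to compound 3 (0.55 log units; beyond the scatter), fluoro in place of chloro on an aromatic carbon.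

Compound 4 `Sc1nnc(-c2ccccc2Br)o1` has not yet been measured. It differs from compound 3 by bromo in place of fluoro on an aromatic carbon. Among the measured compounds shown here, the one measured step that bears on this change is the chloro-to-fluoro step from compound 1 to compound 3, which was modest and pointed toward a lower number; compound 4 moves away from fluoro again, to bromo. For the measured compounds named here, on that basis the step is expected to run the other way, toward a higher number, of roughly similar size, though no bromo compound has been measured here and the width of the range reflects that. Compound 4 is therefore expected to show a 4.2-fold higher number from compound 3 to compound 4 (0.62 log units; beyond the scatter) and to give about 800 nM, with a range from 250 nM to 2500 nM.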

Compound 4, half-maximal inhibitory concentration: 980 nM
The estimate for compound 4 lay 1.2-fold (0.09 log units) below the measured number; the measured number falls inside the stated range.
By their numbers in this assay, from the lowest: compound 3; then compounds 1, 4 and 2 (each within the scatter of the next).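

With the bromo compound in hand, the halogen series at this aromatic carbon in this assay no longer rests on one step, and fluoro stands apart from bromo as it did from chloro: the step is (a 5.2-fold higher number from compound 3 to compound 4 (0.71 log units; beyond the scatter)), beyond the scatter, and so the gain seen with fluoro does not depend on chloro being the partner in the comparison. Chloro and bromo, in contrast, cannot be told apart at this place, since the step between them (a 1.4-fold higher number from compound 1 to compound 4 (0.16 log units; within the scatter)) stays within the scatter, so among these three halogens the read-out separates only fluoro from the other two, and no steady trend runs through all three. Nothing in the data shown gives a reason for this split.

Still open, going by these compounds, is whether a hydrogen, a methoxy group, an amine or a nitrile on this same carbon would fall with fluoro or with the two larger halogens. Also open, on these data alone, is whether the fluoro advantage would survive if the thiol on the shared core gave way to a methylthio group or a hydroxyl group.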